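Swapping an aromatic group for a hexyl chain

This account rests on a few compounds, and the source may have more. Where it says the series, first, only, none or still open, it means among the compounds named here.

Measured in a functional assay on IMR-32 cells (Homo sapiens) for antiproliferative activity, read by sulforhodamine B assay, with a stated time of 48 h; on this read-out lower numbers stand for stronger inhibition of growth and higher numbers for weaker inhibition of growth:
- compound 1 `Cc1ccc(-c2cn(CCCN3C(=O)COc4ccccc43)nn2)cc1`: 4400 nM
- compound 2 `COc1ccc(-c2cn(CCCN3C(=O)COc4ccccc43)nn2)cc1`: 49900 nM

Of these two compounds, compound 2 has the higher number and therefore shows the weaker inhibition of growth. The next compound to be measured is compound 3 `CCCCCCc1cn(CCCN2C(=O)COc3ccccc32)nn1`, which puts hexyl in place of 4-methoxyphenyl on an aromatic carbon. Going by the values given here, this is a bigger edit than any measured so far, and no measured compound carries a hexyl chain.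

Among the compounds with values here, only one measured step bears on it. Swapping methoxy for methyl gave an 11-fold higher number from compound 1 to compound 2 (1.05 log units; beyond the scatter), which shows that even a small edit to this group can shift the number a long way. Compound 1, which has no methoxy, gives 4400 nM. Compound 3 has no methoxy either, so a sizeable move toward lower numbers is expected, though with much uncertainty. The expected move is a 4.2-fold lower number from compound 2 to compound 3 (0.62 log units; beyond the scatter). For compound 3 the estimated value is 12000 nM, with an expected range from 3000 nM to 45000 nM.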

Compound 3, concentration for 50% growth inhibition: 710 nM
Compound 3: middle estimate off by 17-fold (1.23 log units), on the high side; measured number outside the range, below it.
By their numbers in this assay, from the lowest: compound 3; then compound 1; then compound 2.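

In this assay, an aromatic ring at this place on the five-membered aromatic ring turns out not to be needed for inhibition of growth: hexyl, which has no ring, gives the strongest inhibition of the three compounds (a 70-fold lower number from compound 2 to compound 3 (1.85 log units; beyond the scatter)). The gain does not depend on the weak methoxy compound as the point of comparison, since hexyl also beats the 4-methylphenyl group (a 6.2-fold lower number from compound 1 to compound 3 (0.79 log units; beyond the scatter)), so the earlier methyl and methoxy pair had shown only part of the range this position can cover. Nothing available here explains why the number moves in this way.

One flexible chain and two substituted phenyl groups cannot show whether the gain comes from the length of the chain or simply from the loss of the aromatic ring. Butyl, octyl and cyclohexyl at this place would help separate those two readings, and an amine or a hydroxyl at the end of the hexyl chain would show whether the chain tolerates any change at all.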